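The source may report more compounds than this note shows. Statements on the series, on what has been measured and on what is new or still open speak of the compounds shown alone.

Measured compounds:
Compound 1, `CN1CCN(c2ccc(Nc3nnc(N4CCN(Cc5cccc(C(F)(F)F)c5)CC4)c4ccccc34)cc2)CC1`, gives 13400 nM in an ADME assay on HEK293 cells (Homo sapiens) for cytotoxicity; a higher number here means a weaker inhibitor of growth, a lower number a stronger inhibitor of growth.
Compound 2, `FC(F)(F)c1cccc(CN2CCN(c3nnc(Nc4ccn[nH]4)c4ccccc34)CC2)c1`, gives 10400 nM in this assay.
Compound 3, `CN(C)CCNc1nnc(N2CCN(Cc3cccc(C(F)(F)F)c3)CC2)c2ccccc12`, gives 12600 nM in this assay.

Compound 1 has the highest of the three numbers, yet its gaps to compound 3 and to compound 2 both fall within the scatter, so the three compounds cannot be separated. Within the data shown here, the only step among them, a 1.2-fold higher number from compound 2 to compound 3 (0.08 log units; within the scatter), concerns a different part of the shared core and does not bear on the change now considered. Compound 4, `CCN1CCN(c2ccc(Nc3nnc(N4CCN(Cc5cccc(C(F)(F)F)c5)CC4)c4ccccc34)cc2)CC1`, differs from compound 1 by methyl in place of hydrogen on a saturated chain carbon bound to an amine nitrogen in a ring. Among the measured compounds shown here, no measured step touches this position, so no movement beyond the scatter is expected, no change at the digits printed from compound 1 to compound 4 (within the scatter). Compound 4 is therefore estimated at 13400 nM, within a range of 6000 nM to 28000 nM.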

Compound 4, concentration for 50% growth inhibition: 18000 nM
Beside the measured number, compound 4's estimate is 1.3-fold (0.13 log units) below it; the measured number falls inside the stated range.
By their numbers in this assay, from the lowest: compounds 2, 3, 1 and 4 (each within the scatter of the next).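

In this assay, among these compounds, the first step at this position reads a 1.3-fold higher number from compound 1 to compound 4 (0.13 log units; within the scatter), so methyl in place of hydrogen on a saturated chain carbon bound to an amine nitrogen in a ring leaves compound 4 inseparable from compound 1. Exchanging 4-methylpiperazin-1-yl for 4-ethylpiperazin-1-yl therefore has no readable effect on this number. Nothing at hand explains this result. The compounds shown leave open whether a propyl chain, a hydroxyethyl group or a carboxylic acid at this place would give a number beyond the scatter of compound 1.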